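Aryl urea series on rat aorta: chloro for methoxy

The compounds below may be only part of what the source reports. "The series", "measured", "known", "first", "only" and "open" are said of these compounds alone.

Measured so far:
compound 1 `COc1ccccc1NC(=O)NC1CC(C)(C)Oc2ccc(F)cc21` — > 10000 nM
compound 2 `COc1ccccc1NC(=O)NC1CC(C)(C)Oc2ccc(Br)cc21` — > 10000 nM

In a functional assay (aorta) with Rattus norvegicus as the target (on this read-out higher numbers stand for an effect only at larger amounts of compound and lower numbers for an effect already at smaller amounts), compound 1 gives > 10000 nM, which is a limit of the assay and not a number. Compound 2 likewise returns only a limit, > 10000 nM. With both values at the limit of > 10000 nM in this assay, at which 2 of the 2 values shown sit, the bromo-for-fluoro step, a step that the two limits leave unreadable from compound 1 to compound 2, cannot be read in either direction or size.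

Compound 3 `CC1(C)CC(NC(=O)Nc2ccccc2Cl)c2cc(F)ccc2O1` differs from compound 1 by chloro in place of methoxy on an aromatic carbon. Among the compounds with values here, no measured step touches the methoxy group; the only step available in this assay is the unreadable one just named, so nothing anchors the expected change a step that the limit leaves unreadable from compound 1 to compound 3 beyond the scatter. Since compound 1 stands only at a limit, the most likely outcome is that compound 3 also reports a limit. Compound 3 is therefore estimated at 20000 nM, with an expected range from 5000 nM to 100000 nM.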

Compound 3, half-maximal effective concentration: > 30000 nM
Compound 3: only a limit was reported; the forecaster's own chance of this, stated with the estimate: 80%; at least 1.5-fold (0.17 log units) between middle value and limit.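

Within the data shown here, compound 3 gives only a limit of the assay, > 30000 nM, and compound 1 also stands at a limit, so no step between compound 1 and compound 3 can be read in this assay. The compounds shown leave open how chloro and methoxy compare on this read-out, since none has a measured number.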